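Trifluoromethoxy for methyl on the arylamino substituent

The compounds below may be only part of what the source reports. "The series", "measured", "known", "first", "only" and "open" are said of these compounds alone.

Measured compounds:
compound 1 `CCOC1=C(C(=O)c2ccccc2)C(c2ccc(Br)cc2)N(CCCn2ccnc2)C1=O` gives 31700 nM in a functional assay on SAOS-2 cells (Homo sapiens) for antiproliferative activity, read by MTT assay, with a stated time of 72 h; on this read-out higher numbers stand for weaker inhibition and lower numbers for stronger inhibition
compound 2 `CCCCOC1=C(C(=O)c2ccccc2)C(c2ccc(Br)cc2)N(CCCn2ccnc2)C1=O` gives 11600 nM in this assay
compound 3 `Cc1ccc(NC2=C(C(=O)c3ccccc3)C(c3ccc(Br)cc3)N(CCCn3ccnc3)C2=O)cc1` gives 31900 nM in this assay

For the measured compounds named here, compound 3 carries the highest number of the three, but its separation from compound 1 is a 1.0-fold higher number from compound 1 to compound 3 (0.00 log units; within the scatter), so the two cannot be ordered; only the step of a 2.8-fold higher number from compound 2 to compound 3 (0.44 log units; beyond the scatter) stands beyond the scatter. The comparison a 2.7-fold lower number from compound 1 to compound 2 (0.44 log units; beyond the scatter) concerns the alkoxy chain alone.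

Compound 4 `O=C(C1=C(Nc2ccc(OC(F)(F)F)cc2)C(=O)N(CCCn2ccnc2)C1c1ccc(Br)cc1)c1ccccc1` differs from compound 3 by trifluoromethoxy in place of methyl on an aromatic carbon. Going by the values given here, none of the measured steps touches this ring: all three exchange the group on the double-bonded ring carbon of the shared core, and the (4-methylphenyl)amino group itself appears only once. Among the compounds with values here, no step therefore bears directly on the change, and the measured steps are at most modest in size. The expectation for compound 4 is accordingly a number close to that of compound 3, with a step of a 1.1-fold lower number from compound 3 to compound 4 (0.06 log units; within the scatter) that is not expected to exceed the scatter. Compound 4 is estimated at 28000 nM, within 9000 nM to 90000 nM.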

Compound 4, half-maximal inhibitory concentration: 17900 nM
Compound 4: the middle estimate sits 1.6-fold (0.19 log units) above what was measured, within the range that was stated.
By their numbers in this assay, from the lowest: compounds 2, 4, 1 and 3 (each within the scatter of the next, the first and the last beyond it).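

In this assay the arylamino ring now has a measured exchange: trifluoromethoxy in place of methyl, on an aromatic carbon para to a large group, gives a 1.8-fold lower number from compound 3 to compound 4 (0.25 log units; within the scatter) and so stays inside the scatter. The (4-(trifluoromethoxy)phenyl)amino group also cannot be separated from either alkoxy group on the double-bonded ring carbon, with a 1.8-fold lower number from compound 1 to compound 4 (0.25 log units; within the scatter) against ethoxy and a 1.5-fold higher number from compound 2 to compound 4 (0.19 log units; within the scatter) against butoxy, so compound 4 lies within the scatter of compound 2 and compound 3, even though those two differ beyond it. No measurement shown offers an explanation for these numbers.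

As far as these compounds go, whether an amine or a carboxylic acid on this aromatic ring would shift the number remains open, as does the effect of an alkoxy chain longer than butoxy. With only methyl and trifluoromethoxy shown on this ring, no trend across its substituents can be read.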